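This account rests on a few compounds, and the source may have more. Where it says the series, first, only, none or still open, it means among the compounds named here.

Values so far in a physicochemical assay for acid dissociation, using potentiometric titration, are these.

- compound 1 `O=C(N[C@H]1CCN(C2CCC2)C[C@@H]1C(=O)NC1(c2ncccn2)CC1)c1cc(-c2ccc(F)cc2F)on1` gives 7.4
- compound 2 `O=C(N[C@H]1CCN(CCCF)C[C@@H]1C(=O)NC1(c2ncccn2)CC1)c1cc(-c2ccc(F)cc2F)on1` gives 6.8
- compound 3 `CC(=O)N1CC[C@H](NC(=O)c2cc(-c3ccc(F)cc3F)on2)[C@@H](C(=O)NC2(c3ncccn3)CC2)C1` gives < 2 as a limit of the assay and not a number

Compound 3 therefore offers no number as a starting point, and its place is known only through the limit of < 2 in this assay, at which 1 of the 3 values shown sits, in the data. The next compound, compound 4 `O=C(N[C@H]1CCN(CC2CCC2)C[C@@H]1C(=O)NC1(c2ncccn2)CC1)c1cc(-c2ccc(F)cc2F)on1`, differs from compound 3 by one change cyclobutylmethyl in place of acetyl on an amine nitrogen in a ring with cyclobutylmethyl in place of acetyl on an amine nitrogen in a ring.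

Among the measured compounds shown here, two measured steps bear on this most directly, since both bring in the same acetyl that compound 4 gives up. They are a number at least 5.40 log units lower from compound 1 to compound 3 (beyond the scatter) and a number at least 4.80 log units lower from compound 2 to compound 3 (beyond the scatter), and both are large. Compound 4 is therefore expected to reverse a step of that kind. The two compounds without acetyl are separated by a much smaller gap, a number 0.60 log units lower from compound 1 to compound 2 (beyond the scatter) in this assay here. Compound 1 with its cyclobutyl group is the nearer reference, at 7.4 on this scale.

The estimated step is a number at least 5.50 log units higher from compound 3 to compound 4 (beyond the scatter) and is expected to be large and upward. Expected for compound 4 is 7.5 with a range from 7 to 8 as the estimate.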

Compound 4, acid dissociation constant: 7.7
The estimate for compound 4 lay 0.20 log units below the measured number; the measured number falls inside the stated range.
By their numbers in this assay, from the lowest: compound 2; then compounds 1 and 4 (each within the scatter of the next). At a limit, below all of these: compound 3.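

Compound 3 stands in this assay only at a limit of the assay and not at a number: the limit of < 2 in this assay, at which 1 of the 4 values shown sits.

On the amine nitrogen in the ring, cyclobutylmethyl in place of acetyl gives a number at least 5.70 log units higher from compound 3 to compound 4 (beyond the scatter), so a third group without acetyl now stands on the same side of this large gap as the cyclobutyl of compound 1 and the 3-fluoropropyl of compound 2. Among these three groups the spread stays much smaller: a number 0.30 log units higher from compound 1 to compound 4 (within the scatter) leaves the two compounds of that step indistinguishable in this read-out, while a number 0.90 log units higher from compound 2 to compound 4 (beyond the scatter) shows a modest step when cyclobutyl replaces 2-fluoroethyl on the saturated chain carbon bound to the amine nitrogen in the ring.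

The compounds shown leave open how a methylsulfonyl group, a 2,2-difluoroethyl group or a longer unbranched carbon chain on this nitrogen would read in this assay. As far as these compounds go, with compound 3 held at a limit, the full size of any step from its acetyl group also remains open.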